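The source may report more compounds than this note shows. Statements on the series, on what has been measured and on what is new or still open speak of the compounds shown alone.

Series notes. Compound 1 `CC1(C)O[C@H]2O[C@H](Cn3cc(CN4C(=O)C(=O)c5ccccc54)nn3)[C@H](O)[C@H]2O1` in an ADME assay on Vero cells (Chlorocebus sabaeus) for cytotoxicity, read by fluorescence and resazurin assay, with a stated time of 3 days (a higher number here means that more compound is tolerated, a lower number that less compound is tolerated), is reported only as a limit, > 200000 nM, not a number. Compound 2 `CC(=O)C[C@H]1O[C@@H](On2cc(CN3C(=O)/C(=N\Nc4ccccc4)c4ccccc43)nn2)[C@H](OC(C)=O)[C@@H](OC(C)=O)[C@@H]1OC(C)=O` gives 108000 nM in this assay, and compound 3 `CC(=O)C[C@H]1O[C@@H](On2cc(CN3C(=O)/C(=N\Nc4ccccc4)c4ccccc43)nn2)[C@H](OC(C)=O)[C@@H](OC(C)=O)[C@H]1OC(C)=O` gives 65200 nM; the gap a 1.7-fold lower number from compound 2 to compound 3 (0.22 log units; within the scatter) is a drawn-configuration change only (the fact that compounds 2 and 3 differ only in the configuration as drawn), so compound 3 sits within the scatter of compound 2 among the two numbers shown.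

Compound 4 `COc1ccc(N/N=C2\C(=O)N(Cc3cn(O[C@@H]4O[C@H](CC(C)=O)[C@H](OC(C)=O)[C@H](OC(C)=O)[C@H]4OC(C)=O)nn3)c3ccccc32)cc1` carries methoxy in place of hydrogen on an aromatic carbon. No measured step in this assay touches such a change; the single step shown, a 1.7-fold lower number from compound 2 to compound 3 (0.22 log units; within the scatter), concerns configuration alone, so no step beyond the scatter is expected. Compound 4 is therefore expected to show a 1.0-fold lower number from compound 3 to compound 4 (0.00 log units; within the scatter), with an estimated value of 65000 nM in this assay, ranging from 30000 nM to 140000 nM.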

Compound 4, half-maximal cytotoxic concentration: 62500 nM
For compound 4 the middle estimate is 1.0-fold (0.02 log units) above the measured one, and the stated range covers the measured number.
By their numbers in this assay, from the lowest: compounds 4, 3 and 2 (each within the scatter of the next). At a limit, above all of these: compound 1.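

Phenyl to 4-methoxyphenyl, on an aromatic carbon para to a large group, gives a 1.0-fold lower number from compound 3 to compound 4 (0.02 log units; within the scatter) in this assay. Among the compounds shown here, the earlier step concerned drawn configuration only, so this is the first reading of a substituent at this position, and methoxy there cannot be told apart from hydrogen. As far as these compounds go, whether an amine, a carboxylic acid or a longer chain on the same carbon would also stay within the scatter remains open. Nothing on record bears on the reason for this step.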